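Three Inverted Ring Centres in a Benzyl-Protected Sugar Scaffold

The source may hold more compounds than are shown below. What is called first, only, known or untested is meant among the compounds shown, and "the series" means these compounds.

Compound 1, with the structure `CCC[C@@H]1O[C@H](COCc2ccccc2)[C@H](OCc2ccccc2)[C@H](OCc2ccccc2)[C@H]1O`, is the starting point. In a functional assay on HL-60 cells (Homo sapiens) for antiproliferative activity, read by MTT assay (on this read-out higher numbers stand for weaker inhibition and lower numbers for stronger inhibition), compound 1 is recorded as "not active" (no number reported), so no single number describes where it stands, only that it showed no measurable inhibition. A related compound, compound 2 with the structure `C=C[C@@H]1O[C@H](COCc2ccccc2)[C@@H](OCc2ccccc2)[C@H](OCc2ccccc2)[C@H]1O`, does give a number: in this assay compound 2 gives 11800 nM, a weak result on this scale.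

Compound 3, with the structure `CCC[C@H]1O[C@H](COCc2ccccc2)[C@@H](OCc2ccccc2)[C@H](OCc2ccccc2)[C@@H]1O`, has not yet been measured. It is built from the same atoms and bonds as compound 1 and differs only in the drawn configuration: the two compounds have the same atoms and bonds and differ only in configuration as drawn: 3 of 5 stereo elements differ; a stereocentre at a saturated ring carbon is drawn S in compound 1 and R in compound 3; a stereocentre at a saturated ring carbon is drawn S in compound 1 and R in compound 3; a stereocentre at a saturated ring carbon is drawn S in compound 1 and R in compound 3.

Within the data shown here, since compound 1 has no number, no size of step can be computed for it. Within this small set, weak inhibition is the only behaviour seen, so for compound 3 the expectation in this assay is a value in the same weak region, with no shift beyond the scatter that could be pinned down. Compound 3 is therefore expected to give about 20000 nM, within a range from 8000 nM to 60000 nM, and there is a real chance the assay again reports only inactivity.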

Compound 3, half-maximal inhibitory concentration: "not active" (no number reported)
Nothing numeric was reported for compound 3, and the estimate cannot be compared.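

In this assay compound 1 gives "not active" (no number reported) and compound 3 gives "not active" (no number reported), so no step can be read for this closely matched pair: the fact that compounds 1 and 3 differ only in the configuration as drawn. The compounds shown leave open whether the three inverted ring centres change inhibition at all, as neither compound has a number to compare.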